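This account rests on a few compounds, and the source may have more. Where it says the series, first, only, none or still open, it means among the compounds named here.

Measured in the series so far:
compound 1 `Fc1ccc(Cn2cc(CCCOc3cccc4cccnc34)nn2)cc1` – 20.1 ug/mL
compound 2 `Clc1ccc(Cn2cc(CCCOc3cccc4cccnc34)nn2)cc1` – 3.6 ug/mL
compound 3 `Clc1ccc(Br)cc1Cn1cc(CCCOc2cccc3cccnc23)nn1` – 8.2 ug/mL

All three were run in a functional assay on PC-3 cells (Homo sapiens) for inhibition, read by sulforhodamine B assay, with a stated time of 48 h; on this read-out higher numbers stand for weaker inhibition of growth and lower numbers for stronger inhibition of growth. Compound 2 gives the lowest of the three numbers. The nearest neighbour is reached by the step of a 2.3-fold higher number from compound 2 to compound 3 (0.36 log units; beyond the scatter); the furthest by the step of a 5.6-fold lower number from compound 1 to compound 2 (0.75 log units; beyond the scatter), both modest, both beyond the scatter.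

Compound 4 `c1cncc(CCCn2cc(CCCOc3cccc4cccnc34)nn2)c1` has not yet been measured in this assay. Its change from compound 2 is 2-(pyridin-3-yl)ethyl in place of 4-chlorophenyl on a saturated chain carbon bound to an aromatic nitrogen.

Among the measured compounds shown here, no measured step covers this change directly. The step of a 5.6-fold lower number from compound 1 to compound 2 (0.75 log units; beyond the scatter) shows that exchanging one halogen for another on the aromatic carbon moves the number modestly, and the step of a 2.3-fold higher number from compound 2 to compound 3 (0.36 log units; beyond the scatter) shows that altering the aryl group bound to the chain carbon also moves it modestly, there upward. Nothing measured removes the carbon-only ring altogether or introduces a ring with a hetero atom on a longer chain, so the direction rests on the observation that every departure from compound 2 so far has given a higher number.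

Compound 4 is therefore expected to give 12 ug/mL in this assay, within a range of 4 ug/mL to 40 ug/mL. The expected step of a 3.3-fold higher number from compound 2 to compound 4 (0.52 log units; beyond the scatter) is a modest loss.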

Compound 4, concentration for 50% growth inhibition: 26.7 ug/mL
For compound 4 the middle estimate is 2.2-fold (0.35 log units) below the measured one; the range from low to high includes it.
By their numbers in this assay, from the lowest: compound 2; then compound 3; then compounds 1 and 4 (each within the scatter of the next).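

In this assay, a ring with a hetero atom on a longer chain at this saturated chain carbon bound to an aromatic nitrogen does not hold the level of either chlorine-bearing aryl group, as shown by a 7.4-fold higher number from compound 2 to compound 4 (0.87 log units; beyond the scatter) and by a 3.3-fold higher number from compound 3 to compound 4 (0.51 log units; beyond the scatter), so the position accepts this larger group only at a cost relative to those two. Against the fluorine-bearing aryl group the picture differs, with a 1.3-fold higher number from compound 1 to compound 4 (0.12 log units; within the scatter), so 2-(pyridin-3-yl)ethyl and 4-fluorophenyl cannot be told apart here even though they differ in ring type and chain, and compound 2 remains the strongest inhibitor of growth among the four. No measurement at hand accounts for any of these differences.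

From the compounds shown here alone, the change in compound 4 alters the ring and the chain together, so it remains open which of the two carries the step; a phenyl group on the same chain, or a pyridin-3-yl group directly in place of the 4-chlorophenyl, would separate them. Also open, going by these compounds, is how an amine or a carboxylic acid at the end of this chain would read in this assay.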